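The source may report more compounds than this note shows. Statements on the series, on what has been measured and on what is new or still open speak of the compounds shown alone.

Working notes on the series.

Three compounds of this series have been run in a functional assay on HCT-116 cells (Homo sapiens) for cytotoxicity, read by MTT assay, with a stated time of 72 h; a lower number here means a stronger inhibitor, a higher number a weaker inhibitor. Compound 1 `Cc1cc(S(=O)(=O)/N=C(\N)n2nccc2-c2ccccc2)c(SCc2ccc(Cl)cc2)cc1Cl` gives 7000 nM; compound 3 `Cc1cccc(CSc2cc(Cl)c(C)cc2S(=O)(=O)/N=C(\N)n2nccc2-c2ccccc2)c1` gives 6500 nM. For the measured compounds named here, the step of a 1.1-fold lower number from compound 1 to compound 3 (0.03 log units; within the scatter) is the only measured change on the saturated chain carbon bound to a sulfur, and it did not move the number beyond the scatter. Going by the values given here, compound 2 `Cc1cc(-c2ccccc2)n(/C(N)=N/S(=O)(=O)c2cc(C)c(Cl)cc2SCc2ccccc2C)n1` gives 42000 nM and stands highest of the three, beyond the scatter from both compound 1 and compound 3; no single-point step links it to either of them, so its two gaps can only be read as they stand.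

The next compound, compound 4 `Cc1cc(-c2ccccc2)n(/C(N)=N/S(=O)(=O)c2cc(C)c(Cl)cc2SCc2ccc(C(F)(F)F)cc2)n1`, is unmeasured. It differs from compound 2 by 4-(trifluoromethyl)phenyl in place of 2-methylphenyl on a saturated chain carbon bound to a sulfur. Among the compounds with values here, the one step that bears on a change at this position, from compound 1 to compound 3, was within the scatter, though it swapped different groups and sat on a different core. Nothing measured here argues for a move in either direction, so the expected step of a 1.4-fold lower number from compound 2 to compound 4 (0.15 log units; within the scatter) is none beyond the scatter, with a wide range to cover the lack of a direct precedent. Compound 4 is therefore estimated at 30000 nM, spanning 9000 nM to 90000 nM.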

Compound 4, half-maximal inhibitory concentration: 7000 nM
Compound 4: middle estimate off by 4.3-fold (0.63 log units), on the high side, and the stated range ends above it.
By their numbers in this assay, from the lowest: compounds 3, 1 and 4 (each within the scatter of the next); then compound 2.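

In this assay, for the compounds shown here, the step of a 6.0-fold lower number from compound 2 to compound 4 (0.78 log units; beyond the scatter) is the first measured change on a saturated chain carbon bound to a sulfur that lies beyond the scatter, so this place can move the number, which the step of a 1.1-fold lower number from compound 1 to compound 3 (0.03 log units; within the scatter) gave no sign of. The two steps swap different groups on different cores, so they set no general rule for this place: the new step holds only for 4-(trifluoromethyl)phenyl in place of 2-methylphenyl on the core of compound 2. No measurement is at hand that accounts for this step, and no cause can be given for it.

The step alone cannot separate the loss of 2-methylphenyl from the gain of 4-(trifluoromethyl)phenyl, and a plain phenyl or a 4-methylphenyl at the same place on the core of compound 2 would help to tell the two apart. On these data alone, it also remains open whether 4-(trifluoromethyl)phenyl would shift the number on the core of compound 1, and how a carboxylic acid or an amine on this ring would read in this assay.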